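This account rests on a few compounds, and the source may have more. Where it says the series, first, only, none or still open, it means among the compounds named here.

Measured in an in vitro ADME assay on microsomes from liver (Rattus norvegicus) for metabolic stability, tested at 2 uM; on this read-out lower numbers stand for a shorter-lived compound and higher numbers for a longer-lived compound:
- compound 1 `CC(C)(O)C#Cc1ccc(NC(=O)CSc2nnnn2-c2ccc(C3CC3)cc2Cl)c(Cl)c1`: 1.4 h
- compound 2 `CC(C)(N)C#Cc1ccc(NC(=O)CSc2nnnn2-c2ccc(C3CC3)cc2Cl)c(Cl)c1`: 0.517 h
- compound 3 `CC(C)(C#Cc1ccc(NC(=O)CSc2nnnn2-c2ccc(C3CC3)cc2Cl)c(Cl)c1)CNCC(=O)O`: 1.32 h

Compound 3, at 1.32 h, is second highest of the three numbers, though only one of its two gaps counts. The step of a 1.1-fold lower number from compound 1 to compound 3 (0.03 log units; within the scatter) does not set it apart, whereas the step of a 2.6-fold higher number from compound 2 to compound 3 (0.41 log units; beyond the scatter) does.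

Compound 4 `CC(C)(C#Cc1ccc(NC(=O)CSc2nnnn2-c2ccc(C3CC3)cc2Cl)c(Cl)c1)CC(=O)O` differs from compound 3 at one place, with carboxy in place of (carboxymethyl)amino on a saturated chain carbon, two bonds along the chain from a triple-bonded carbon.

For the measured compounds named here, no measured step makes this exact change, but all three measured steps fall in the same region of the molecule. Besides the two above, there is the step of a 2.7-fold lower number from compound 1 to compound 2 (0.43 log units; beyond the scatter). Going by the values given here, the largest of them is modest, and the only low number belongs to compound 2, which carries amino, a group absent from compound 4. The expected step is therefore none beyond the scatter: a 1.0-fold lower number from compound 3 to compound 4 (0.01 log units; within the scatter).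

Compound 4 is estimated at 1.3 h, with an expected range of 0.7 h to 2.4 h.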

Compound 4, half-life: 0.35 h
For compound 4 the middle estimate is 3.7-fold (0.57 log units) above the measured one; measured number outside the range, below it.
By their numbers in this assay, from the lowest: compounds 4 and 2 (each within the scatter of the next); then compounds 3 and 1 (each within the scatter of the next).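

In this assay, a carboxylic acid at the end of this chain does not by itself hold the number seen for compound 3: the change gives a 3.8-fold lower number from compound 3 to compound 4 (0.58 log units; beyond the scatter), and set against the hydroxy group it gives a 4.0-fold lower number from compound 1 to compound 4 (0.60 log units; beyond the scatter). Short half-lives are therefore no longer confined to the amino group, and a 1.5-fold lower number from compound 2 to compound 4 (0.17 log units; within the scatter) places compound 4 with compound 2, although the two groups have little in common. Nothing available here accounts for the drop.

The change removes the amine nitrogen and shortens the chain together, and the compounds shown do not separate these two differences. As far as these compounds go, it remains open how a carboxylic acid on an all-carbon chain as long as that of compound 3 would behave, or a primary amide in place of the carboxylic acid of compound 4.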